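The compounds below may be only part of what the source reports. "The series", "measured", "known", "first", "only" and "open" are said of these compounds alone.

Of the compounds shown here, three have been tested in an ADME assay on MT4 cells (Homo sapiens) for cytotoxicity, read by MTT assay; a higher number here means that more compound is tolerated, a lower number that less compound is tolerated. Compound 1 `COc1ccc(OC)c2c1c(C(=O)/C=C(\O)C(=O)O)cn2Cc1ccc(F)cc1` gives 213000 nM, compound 2 `CCOC(=O)/C(O)=C/C(=O)c1cn(Cc2ccc(F)cc2)c2ccc(OC)cc12` gives 126000 nM, and compound 3 `CCOC(=O)/C(O)=C/C(=O)c1cn(Cc2ccc(F)cc2)c2cc(OC)ccc12` gives 100000 nM. Compound 3 stands at the lowest of these three numbers; its gap to compound 2 lies within the scatter of repeated measurements, while compound 1 sits beyond the scatter above it.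

Compound 4 `COc1ccc2c(C(=O)/C=C(\O)C(=O)O)cn(Cc3ccc(F)cc3)c2c1` has not yet been measured. It differs from compound 3 in one place: hydrogen in place of ethyl on an oxygen next to a carbonyl group. Compound 1 carries the same carboxy group rather than an ethoxycarbonyl group, and it shows the higher number, but compound 1 also differs from compound 3 elsewhere, so that pair on its own cannot settle the matter.

For compound 4 the step of a 1.7-fold higher number from compound 3 to compound 4 (0.23 log units; within the scatter) is expected to be a modest rise, near the edge of the scatter. Compound 4 is therefore estimated at 170000 nM, with a range from 85000 nM to 340000 nM.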

Compound 4, half-maximal cytotoxic concentration: 66000 nM
Compound 4: middle estimate off by 2.6-fold (0.41 log units), on the high side; measured number below the stated range.
By their numbers in this assay, from the lowest: compounds 4, 3, 2 and 1 (each within the scatter of the next, the first and the last beyond it).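

In this assay, putting hydrogen in place of ethyl on an oxygen next to a carbonyl group, which turns ethoxycarbonyl into carboxy, gives a 1.5-fold lower number from compound 3 to compound 4 (0.18 log units; within the scatter) and so does not separate the two groups. This is the first pair among these compounds that differs only in this one place, and it gives no clear sign that either group is better tolerated on this core. No measurement shown here speaks to the reason for this result.

On these data alone, what a longer chain on this oxygen, or an amide in place of the carboxy group, would give remains open. As far as these compounds go, it is also open whether the same change would read alike on the core of compound 2 or on the core of compound 1.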